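Sulfonyl groups on a quinolone core: inactivity at every limit

The source may report more compounds than this note shows. Statements on the series, on what has been measured and on what is new or still open speak of the compounds shown alone.

Compound 1 `COc1ccc(-c2cc(=O)c3c(OC)cc(OC)cc3[nH]2)cc1` is the parent of this small set. In an ADME assay on BJ cells (Homo sapiens) for antiproliferative activity, with a stated time of 72 h (on this read-out higher numbers stand for an effect only at larger amounts of compound and lower numbers for an effect already at smaller amounts), compound 1 gives > 62000 nM, which is a limit of the measurement and not a number. Compound 2 `COc1ccc(-c2cc(=O)c3c(OC)cc(OC)cc3n2S(=O)(=O)c2ccc(C)c([N+](=O)[O-])c2)cc1` carries a 4-methyl-3-nitrophenyl sulfonyl group on the aromatic nitrogen. In this assay compound 2 gives > 51700 nM, again only a limit. Compound 3 `COc1ccc(-c2cc(=O)c3c(OC)cc(OC)cc3n2S(=O)(=O)c2ccc(C#N)cc2)cc1` carries a 4-cyanophenyl sulfonyl group at the same position. In this assay compound 3 gives > 17200 nM, also a limit.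

Because all three values sit at limits (the limit of > 62000 nM in this assay, at which 1 of the 3 values shown sits, (the limit of > 51700 nM in this assay, at which 1 of the 3 values shown sits), (the limit of > 17200 nM in this assay, at which 1 of the 3 values shown sits)), neither step can be read: a step that the two limits leave unreadable from compound 1 to compound 3 and a step that the two limits leave unreadable from compound 2 to compound 3 stay of unknown size.

Compound 4 `COc1ccc(-c2cc(=O)c3c(OC)cc(OC)cc3n2S(=O)(=O)c2cccc(Br)c2)cc1` differs from compound 1 by (3-bromophenyl)sulfonyl in place of hydrogen on an aromatic nitrogen. The two measured sulfonyl additions show no readable effect, so no shift beyond the scatter is expected for an at least 1.2-fold lower number from compound 1 to compound 4 (0.09 log units; that floor lies within the scatter). Compound 4 is therefore estimated at 50000 nM in this assay, with a range from 20000 nM to 100000 nM, most likely reported as a limit.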

Compound 4, half-maximal effective concentration: > 58600 nM
Compound 4 gave a limit, no number; the forecaster's own chance of this, stated with the estimate: 85%; middle value at least 1.1-fold (0.06 log units) away from the limit.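

Compound 4 also gives only a limit in this assay, so its steps from compound 1, compound 2 and compound 3 cannot be read. The compounds shown leave open whether any sulfonyl group on the aromatic nitrogen changes the effect on these cells.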